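Amine replacement on the shared core, toward compound 3

The source may report more compounds than this note shows. Statements on the series, on what has been measured and on what is new or still open speak of the compounds shown alone.

Compound 1 `OCCCNc1ncnc2[nH]cc(-c3cccc(Cl)c3)c12` gives 94 nM in an assay for inhibition of serine/threonine-protein kinase 4 (Homo sapiens), read by luminescence and ADP-Glo, in the presence of a further agent that is not named here; on this read-out lower numbers stand for stronger inhibition and higher numbers for weaker inhibition. For the measured compounds named here, its only comparator is compound 2 `Clc1cccc(-c2c[nH]c3ncnc(N4CCCCC4)c23)c1`, which in this assay gives 48 nM; the step of a 2.0-fold lower number from compound 1 to compound 2 (0.29 log units; within the scatter) remains within the scatter, so no order between compound 1 and compound 2 can be read from these two numbers, and compound 1 stands simply as one of two values that sit within the scatter of each other.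

Compound 3 `CC(CO)CN(C)c1ncnc2[nH]cc(-c3cccc(Cl)c3)c12` has not yet been measured in this assay. It differs from compound 1 in one place: a group of 7 heavy atoms (5 carbon, 1 nitrogen, 1 oxygen; no ring) in place of a group of 5 heavy atoms (3 carbon, 1 nitrogen, 1 oxygen; no ring), on an aromatic carbon. Going by the values given here, the single measured step that bears on this change is a 2.0-fold lower number from compound 1 to compound 2 (0.29 log units; within the scatter), in which the (3-hydroxypropyl)amino on the same aromatic carbon was also exchanged for another nitrogen-linked group, and the number moved by less than the scatter. On that basis no step beyond the scatter is expected for compound 3 in this assay, with at most a slight lowering of the number in line with the earlier exchange.

Compound 3 is therefore estimated at 75 nM in this assay, with a range from 25 nM to 220 nM. This estimate means an expected step of a 1.3-fold lower number from compound 1 to compound 3 (0.10 log units; within the scatter).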

Compound 3, half-maximal inhibitory concentration: 38 nM
Compound 3: middle estimate off by 2.0-fold (0.30 log units), on the high side; the range from low to high includes it.
By their numbers in this assay, from the lowest: compounds 3, 2 and 1 (each within the scatter of the next, the first and the last beyond it).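

In this assay, for the compounds shown here, the open-chain group of compound 3 gives the first step beyond the scatter at this aromatic carbon: a 2.5-fold lower number from compound 1 to compound 3 (0.39 log units; beyond the scatter), a modest change, whereas replacing the same (3-hydroxypropyl)amino with piperidin-1-yl did not clear the scatter. The new group differs from (3-hydroxypropyl)amino in both heavy-atom count and hydrogen-bond donor count, so this single step cannot assign the change to either difference, and no measurement available here accounts for it. The step of a 1.3-fold lower number from compound 2 to compound 3 (0.10 log units; within the scatter) lies within the scatter, so the open chain of compound 3 and the piperidin-1-yl ring of compound 2 cannot be ordered, and at this position a ring is not needed to reach values of this size in these compounds.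

On these data alone, it remains open which added carbon carries the step, and a (3-hydroxypropyl)(methyl)amino group or a (3-hydroxy-2-methylpropyl)amino group would separate the methyl on the nitrogen from the methyl on the chain. Also open, as far as these compounds go, is how this aromatic carbon responds to morpholin-4-yl, to a longer chain, or to a chain ending in a carboxylic acid.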